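This account rests on a few compounds, and the source may have more. Where it says the series, first, only, none or still open, it means among the compounds named here.

Compound 1 (`COc1cc2c(Oc3ccc(NC(=O)Nc4cccc(C)c4)cc3)ccnc2cc1OCCCCCCC(=O)NO`): 1240 nM 
Compound 2 (`COc1cc2c(Oc3ccc(NC(=O)NC4CCCCC4)cc3)ccnc2cc1OCCCCCCC(=O)NO`): 600 nM 

Within the data shown here, in a functional assay on MCF7 cells (Homo sapiens) for antiproliferative activity, read by MTT assay (a lower number here means a stronger inhibitor, a higher number a weaker inhibitor), compound 2 holds the lower of the two numbers, and the only measured comparison is a 2.1-fold lower number from compound 1 to compound 2 (0.32 log units; beyond the scatter), with cyclohexyl in place of 3-methylphenyl on an amide-type nitrogen.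

Compound 3 (`COc1ccccc1NC(=O)Nc1ccc(Oc2ccnc3cc(OCCCCCCC(=O)NO)c(OC)cc23)cc1`) changes the same place: 2-methoxyphenyl in place of cyclohexyl on an amide-type nitrogen. The expectation rests on that single modest step, in which compound 1, with its aromatic ring at this place, gives 1240 nM against the lower number of compound 2. Among the measured compounds shown here, no measured compound shows what the 2-methoxyphenyl group itself does, so the read-across from 3-methylphenyl is uncertain. A rise of similar modest size in this assay is therefore expected, returning to about the level of compound 1. The estimated move is a 1.8-fold higher number from compound 2 to compound 3 (0.26 log units; within the scatter), in the direction of a higher number. For compound 3 the estimated value is 1100 nM, with an expected range from 450 nM to 2600 nM.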

Compound 3, half-maximal inhibitory concentration: 6280 nM
Compound 3: middle estimate off by 5.7-fold (0.76 log units), on the low side; measured number outside the range, above it.
By their numbers in this assay, from the lowest: compound 2; then compound 1; then compound 3.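

At this amide-type nitrogen, in this assay, 2-methoxyphenyl in place of cyclohexyl gives a 10-fold higher number from compound 2 to compound 3 (1.02 log units; beyond the scatter), so this position can move the number much further than the first pair showed. The two aromatic groups also do not read alike: 2-methoxyphenyl in place of 3-methylphenyl gives a 5.1-fold higher number from compound 1 to compound 3 (0.70 log units; beyond the scatter), a larger step than the one separating 3-methylphenyl and cyclohexyl, so the presence of an aromatic ring at this place does not alone set the number. Nothing available bears on why 2-methoxyphenyl stands so far from the other two groups.

The compounds shown leave open whether the rise in compound 3 follows from the methoxy group itself or from where it sits on the ring, a question that phenyl, 2-methylphenyl and 3-methoxyphenyl at the same nitrogen would separate. They also leave open whether cyclohexyl is a single case or whether other saturated groups, such as cyclopentyl or a plain hexyl chain, also hold the number near that of compound 2 600 nM.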